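The source may report more compounds than this note shows. Statements on the series, on what has been measured and on what is new or still open speak of the compounds shown alone.

Measurements in a physicochemical assay for lipophilicity, read by HPLC, at pH 7.4 (on this read-out lower numbers stand for lower lipophilicity and higher numbers for higher lipophilicity), exist for three compounds. Compound 1 `Cc1ccc(-n2nccn2)c(C(=O)N2CSC[C@H]2Cn2ccc(-c3ccc(F)cn3)n2)c1` gives 3.08 and compound 2 `Cc1ccc(-n2nccn2)c(C(=O)N2CCCO[C@H]2Cn2cc(-c3ccc(F)cc3)cn2)c1` gives 3.15 on this scale. Compound 3 `Cc1ccc(-c2ncccn2)c(C(=O)N2CCCO[C@H]2Cn2ccc(-c3ccc(F)cn3)n2)c1` gives 2.36 as the lowest of the three numbers, and it sits beyond the usual scatter of repeated measurements from both of the others.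

Compound 4 `O=C(c1cc(F)ccc1-c1ncccn1)N1CCCO[C@H]1Cn1ccc(-c2ccc(F)cn2)n1` is compound 3 with a single change (fluoro in place of methyl on an aromatic carbon): fluoro in place of methyl on an aromatic carbon, meta to a large group and para to a pyrimidin-2-yl group. Among the measured compounds shown here, no measured pair differs in one place only, so the data hold no direct measure of this swap. Compound 3 at 2.36 is therefore the starting point, and only a small downward move is expected. In this assay that expected step (a number 0.16 log units lower from compound 3 to compound 4 (within the scatter)) is small enough to stay within the scatter. The estimated value for compound 4 is 2.2 with an expected range from 1.9 to 2.5 on this scale.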

Compound 4, distribution coefficient: 2.3
The estimate for compound 4 lay 0.10 log units below the measured number, within the range that was stated.
By their numbers in this assay, from the lowest: compounds 4 and 3 (each within the scatter of the next); then compounds 1 and 2 (each within the scatter of the next).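

Among the compounds shown here, compounds 3 and 4 are the only pair here that differ in one place, so they give the first direct reading of fluoro in place of methyl on an aromatic carbon, meta to a large group and para to a pyrimidin-2-yl group. In this assay this swap gives a number 0.06 log units lower from compound 3 to compound 4 (within the scatter) and so, at this position, the two groups cannot be told apart on this read-out. No other measurement bears on this result.

The compounds shown leave open whether a different group at this position, such as a nitrile or an amine, would shift the number beyond the scatter. They also leave open whether the same swap would read alike if a different group replaced the pyrimidin-2-yl group.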